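Chlorophenyl for methylphenyl on the ring nitrogen

The source may hold more compounds than are shown below. What is called first, only, known or untested is meant among the compounds shown, and "the series" means these compounds.

Compound 1, `O=c1[nH]cc(S(=O)(=O)Nc2ccccc2-c2cn(-c3ccccc3F)nn2)c(=O)[nH]1`: > 100000 nM in an ADME assay on GES1 cells (Homo sapiens) for cytotoxicity, read by MTT assay, with a stated time of 24 h; on this read-out higher numbers stand for lower toxicity in this test and lower numbers for higher toxicity in this test
Compound 2, `O=c1[nH]cc(S(=O)(=O)Nc2ccccc2-c2cn(-c3ccccc3Cl)nn2)c(=O)[nH]1`: 20800 nM
Compound 3, `Cc1cccc(-n2cc(-c3cccc(NS(=O)(=O)c4c[nH]c(=O)[nH]c4=O)c3)nn2)c1`: 18500 nM

The value of compound 1 is a limit of this assay, not a number. Compound 3 stands close to compound 2, within the usual scatter. Going by the values given here, the one measured step, an at least 4.8-fold lower number from compound 1 to compound 2 (0.68 log units; beyond the scatter), exchanges one halogen for another on the phenyl and does not bear on the change at hand. Compound 4, `O=c1[nH]cc(S(=O)(=O)Nc2cccc(-c3cn(-c4ccccc4Cl)nn3)c2)c(=O)[nH]1`, differs from compound 3 by 2-chlorophenyl in place of 3-methylphenyl on an aromatic nitrogen. Among the compounds with values here, no measured pair shows this exchange, and compound 2 already carries 2-chlorophenyl with a value close to compound 3. Compound 4 is therefore expected to show a 1.1-fold higher number from compound 3 to compound 4 (0.03 log units; within the scatter), none beyond the scatter. Compound 4 is estimated at 20000 nM in this assay, between 7000 nM and 60000 nM.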

Compound 4, half-maximal cytotoxic concentration: 14000 nM
Estimate against measurement, compound 4: 1.4-fold (0.15 log units) above, within the range that was stated.
By their numbers in this assay, from the lowest: compounds 4, 3 and 2 (each within the scatter of the next). At a limit, above all of these: compound 1.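

On the aromatic nitrogen of the shared core, 2-chlorophenyl in place of 3-methylphenyl gives a 1.3-fold lower number from compound 3 to compound 4 (0.12 log units; within the scatter) in this assay. Unlike the halogen exchange seen earlier, this exchange of phenyl groups therefore leaves the two compounds indistinguishable in this test. Nothing measured here gives a cause for this result.

On these data alone, whether an aminophenyl or a carboxyphenyl group at this position would move the number beyond the scatter remains open. So does the separate contribution of the chlorine and of its place on the phenyl.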